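Carbonyl substituent changes on the shared core

The source may hold more compounds than are shown below. What is called first, only, known or untested is meant among the compounds shown, and "the series" means these compounds.

Compound 2 `CN(C(=O)c1ccc(F)cc1)c1ccc2[nH]c(-c3n[nH]c4ccccc34)cc2n1` carries 4-fluorophenyl on the carbonyl carbon of the amide-type nitrogen. In a functional assay on HL-60 cells (Homo sapiens) for antiproliferative activity, read by MTT assay, with a stated time of 72 h (a higher number here means a weaker inhibitor, a lower number a stronger inhibitor), compound 2 gives 1210 nM, the second highest of the three numbers; compound 3 `CN(c1ccc2[nH]c(-c3n[nH]c4ccccc34)cc2n1)S(=O)(=O)c1ccc(OC(F)(F)F)cc1` gives 1170 nM, within the scatter of compound 2, while compound 1 `CN(C(=O)CCc1ccccc1)c1ccc2[nH]c(-c3n[nH]c4ccccc34)cc2n1` gives 4730 nM. For the measured compounds named here, the only measured step, a 3.9-fold lower number from compound 1 to compound 2 (0.59 log units; beyond the scatter), alters the same carbonyl carbon. Compound 4 `CN(C(=O)Nc1ccccc1)c1ccc2[nH]c(-c3n[nH]c4ccccc34)cc2n1` is anilino in place of 4-fluorophenyl on a carbonyl carbon. Going by the values given here, no measured pair replaces 4-fluorophenyl by anilino, so that step bears on compound 4 only as a sign that this position tolerates change without large swings. The estimated 1.2-fold higher number from compound 2 to compound 4 (0.09 log units; within the scatter) is expected to stay within the scatter. The estimate for compound 4 is 1500 nM, with a range from 600 nM to 4000 nM.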

Compound 4, half-maximal inhibitory concentration: 8.3 nM
For compound 4 the middle estimate is 180-fold (2.26 log units) above the measured one; measured number below the stated range.
By their numbers in this assay, from the lowest: compound 4; then compounds 3 and 2 (each within the scatter of the next); then compound 1.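

For the compounds shown here, the carbonyl carbon is far more sensitive to change than the earlier compounds indicated: in this assay the anilino change gives a 150-fold lower number from compound 2 to compound 4 (2.16 log units; beyond the scatter) and a 570-fold lower number from compound 1 to compound 4 (2.76 log units; beyond the scatter). Anilino replaces 4-fluorophenyl with no change in heavy-atom count but brings a hydrogen-bond donor, a difference that coincides with the large step without explaining it. No supporting measurement accounts for the gain. On these data alone, whether the amide hydrogen is needed remains open, and a methyl group on the anilino nitrogen would test this. Also open, as far as these compounds go, is how 4-fluoroanilino or benzylamino would compare with anilino.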